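Trifluoromethoxy for trifluoromethyl, repeated on a second core

The source may hold more compounds than are shown below. What is called first, only, known or untested is meant among the compounds shown, and "the series" means these compounds.

Compound 1 `CC(O)(CSc1ccc(C(F)(F)F)cc1)C(=O)Nc1cccc(S(F)(F)(F)(F)F)c1` gives 26900 nM in a functional assay on CWR22R cells (Homo sapiens) for antiproliferative activity, read by propidium iodide staining, with a stated time of 96 h; on this read-out lower numbers stand for stronger inhibition and higher numbers for weaker inhibition. Compound 2 `CC(O)(CSc1ccc(OC(F)(F)F)cc1)C(=O)Nc1cccc(S(F)(F)(F)(F)F)c1` carries the change trifluoromethoxy in place of trifluoromethyl on an aromatic carbon and in this assay compound 2 gives 17000 nM, the step being a 1.6-fold lower number from compound 1 to compound 2 (0.20 log units; within the scatter). Compound 3 `CC(O)(COc1ccccc1C(F)(F)F)C(=O)Nc1ccc(S(F)(F)(F)(F)F)cc1` has a different core; the difference between the two cores is not broken down here. In this assay compound 3 gives 1400 nM, the lowest number of the three, its steps to both others lying beyond the scatter.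

Compound 4 `CC(O)(COc1ccccc1OC(F)(F)F)C(=O)Nc1ccc(S(F)(F)(F)(F)F)cc1` differs from compound 3 by trifluoromethoxy in place of trifluoromethyl on an aromatic carbon. This is the same kind of change as from compound 1 to compound 2, but the place differs: there it is para to a large group, here ortho to a large group. Resting on the single prior step a 1.6-fold lower number from compound 1 to compound 2 (0.20 log units; within the scatter), compound 4 is expected to move by about a 1.4-fold lower number from compound 3 to compound 4 (0.15 log units; within the scatter), within the scatter. Compound 4 is therefore estimated at 1000 nM, between 350 nM and 3000 nM.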

Compound 4, half-maximal inhibitory concentration: 7300 nM
Compound 4: the middle estimate sits 7.3-fold (0.86 log units) below what was measured; the measured number lies above the stated range.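

In this assay, trifluoromethoxy in place of trifluoromethyl on the core of compound 3 gives a 5.2-fold higher number from compound 3 to compound 4 (0.72 log units; beyond the scatter). The change therefore does not carry over with the same outcome between these two cores: the same change on two cores in this assay, a 1.6-fold lower number (0.20 log units; within the scatter) from compound 1 to compound 2 and a 5.2-fold higher number (0.72 log units; beyond the scatter) from compound 3 to compound 4, 8.3-fold (0.92 log units) apart, beyond the scatter of two such steps. The two pairs differ from each other in more than one place, including where the changed group sits, so they do not show which difference governs the outcome, and two pairs give no general rule for the series.

Still open, as far as these compounds go, is whether the change would behave alike with the group kept in one place on a single core. Also open, from the compounds shown here alone, is whether a nitrile or a carboxylic acid at that site would match trifluoromethyl on the core of compound 3.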